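A few compounds are considered here, and "the series" means these few. Any claim that something is new, unique, unknown or untested is made for them only; others in the source may bear on it.

Measured so far in an assay on a protein complex for activation of soluble guanylate cyclase (Homo sapiens), read by cGMP accumulation, in the presence of a further agent that is not named here; on this read-out lower numbers stand for an effect already at smaller amounts and higher numbers for an effect only at larger amounts of compound:
compound 1 `Fc1ccccc1Cn1nc(-c2ncc(F)c(N3CCCC3)n2)cc1-c1ccon1` gives 83 nM;
compound 2 `Fc1ccccc1Cn1nc(-c2ncc(F)c(N3CCCCC3)n2)cc1-c1ccon1` gives 27 nM;
compound 3 `OCC1CCCCN1c1nc(-c2cc(-c3ccon3)n(Cc3ccccc3F)n2)ncc1F` gives 35 nM.

Compound 2 holds the smallest of the three numbers in this assay, but only the gap to compound 1 separates it clearly: a 3.1-fold lower number from compound 1 to compound 2 (0.49 log units; beyond the scatter), while a 1.3-fold higher number from compound 2 to compound 3 (0.11 log units; within the scatter), so compound 2 and compound 3 cannot be told apart on these data. Compound 1 is also set apart from compound 3: a 2.4-fold lower number from compound 1 to compound 3 (0.38 log units; beyond the scatter).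

The next compound is compound 4 `Fc1ccccc1Cn1nc(-c2ncc(F)c(N3CCNCC3)n2)cc1-c1ccon1`, which differs from compound 2 in one place: piperazin-1-yl in place of piperidin-1-yl on an aromatic carbon.

Within the data shown here, no measured step exchanges a ring carbon for a ring nitrogen in this part of the series. The closest hints are the growth of the saturated ring, a 3.1-fold lower number from compound 1 to compound 2 (0.49 log units; beyond the scatter), and the placement of a polar group on it, a 1.3-fold higher number from compound 2 to compound 3 (0.11 log units; within the scatter), which left the number essentially unchanged. Together these suggest the six-membered saturated ring at this aromatic carbon is the favourable size and tolerates a hydrogen-bond donor, so for compound 4 the expected step is small, at most slightly towards a higher number, a 1.9-fold higher number from compound 2 to compound 4 (0.27 log units; within the scatter). The estimate for compound 4 in this assay is 50 nM, with a range from 18 nM to 160 nM.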

Compound 4, half-maximal effective concentration: 120 nM
The estimate for compound 4 lay 2.4-fold (0.38 log units) below the measured number; the range from low to high includes it.
By their numbers in this assay, from the lowest: compounds 2 and 3 (each within the scatter of the next); then compounds 1 and 4 (each within the scatter of the next).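

In this assay, a six-membered saturated ring at this aromatic carbon, ortho to a fluoro group, does not by itself secure the lower numbers: exchanging one ring carbon of piperidin-1-yl for a ring nitrogen gives the first clear loss among the six-membered rings (a 4.4-fold higher number from compound 2 to compound 4 (0.65 log units; beyond the scatter)). The same position accepted hydroxymethyl on the piperidine ring without a step beyond the scatter, yet piperazin-1-yl stands clearly apart from that group as well (a 3.4-fold higher number from compound 3 to compound 4 (0.54 log units; beyond the scatter)), so an added heteroatom in the substituent does not have one uniform outcome here: what matters is which atom is added and where it sits. Piperazin-1-yl also gives up the whole advantage of the larger ring, with no separation from the five-membered pyrrolidin-1-yl (a 1.4-fold higher number from compound 1 to compound 4 (0.16 log units; within the scatter)), and nothing available explains this step.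

Still open, from the compounds shown here alone, is whether the higher number follows the ring nitrogen itself or the hydrogen it carries, a question that 4-methylpiperazin-1-yl or an acetyl group on that nitrogen would address. Morpholin-4-yl, with a ring oxygen at the same place, would show whether a ring nitrogen is needed for the step at all.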